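Compound 3: a benzoxazole swap on compound 2

A few compounds are considered here, and "the series" means these few. Any claim that something is new, unique, unknown or untested is made for them only; others in the source may bear on it.

Compound 1 `CCN(CC)CCn1c(N)c(-c2nc3ccccc3[nH]2)c2nc(C#N)c(C#N)nc21`: > 50000 nM
Compound 2 `CCN(CC)CCCCn1c(N)c(-c2nc3ccccc3[nH]2)c2nc(C#N)c(C#N)nc21`: 5750 nM

Among the measured compounds shown here, in a functional assay on A549 cells (Homo sapiens) for antiproliferative activity, read by MTT assay, with a stated time of 48 h (on this read-out higher numbers stand for weaker inhibition and lower numbers for stronger inhibition), compound 2 gives 5750 nM, the only true number so far. For compound 1 the reading is a limit: > 50000 nM. For the measured compounds named here, the one measured step, an at least 8.6-fold lower number from compound 1 to compound 2 (0.93 log units; beyond the scatter), concerns the chain, not the group that changes next, so it offers no size to carry over. Compound 3 `CCN(CC)CCCCn1c(N)c(-c2nc3ccccc3o2)c2nc(C#N)c(C#N)nc21` keeps the 4-(diethylamino)butyl group of compound 2, and the change is 1,3-benzoxazol-2-yl in place of 1H-benzimidazol-2-yl on an aromatic carbon. With no measured guide, no shift beyond the scatter is expected in this assay. The expected step is a 1.2-fold higher number from compound 2 to compound 3 (0.09 log units; within the scatter). Compound 3 is estimated at 7000 nM, within a range of 2000 nM to 25000 nM.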

Compound 3, half-maximal inhibitory concentration: 9390 nM
For compound 3 the middle estimate is 1.3-fold (0.13 log units) below the measured one; low and high end bracket the measured number.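

In this assay the change gives a 1.6-fold higher number from compound 2 to compound 3 (0.21 log units; within the scatter) and so shows that, on this aromatic carbon, 1,3-benzoxazol-2-yl can stand in for 1H-benzimidazol-2-yl without a shift beyond the scatter. The entering group has no hydrogen-bond donor, so the donor of the leaving group is not shown to be needed here. Nothing measured here explains this result.

Still open, on these data alone, is how 1,3-benzothiazol-2-yl, with sulfur in place of the oxygen, would read at this place. Also open, as far as these compounds go, is whether a simple phenyl ring would hold up as well.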